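This account rests on a few compounds, and the source may have more. Where it says the series, first, only, none or still open, it means among the compounds named here.

In a functional assay on HeLa cells (Homo sapiens) for antiproliferative activity, read by CCK-8 assay, with a stated time of 72 h, tested at 8 uM (on this read-out higher numbers stand for a stronger effect at the one concentration tested and lower numbers for a weaker effect), compound 1 `Nc1ccccc1NC(=O)c1ccc(CSC(=S)N2CCN(c3ccc(Cl)cc3)CC2)cc1` gives 44.8%, compound 2 `Nc1ccccc1NC(=O)c1ccc(CSC(=S)N2CCN(c3ccccc3)CC2)cc1` gives 73.1%, and compound 3 `Cc1ccc(N2CCN(C(=S)SCc3ccc(C(=O)Nc4ccccc4N)cc3)CC2)cc1` gives 24%, the lowest of the three numbers, with compound 1 its nearest neighbour. The step of a number 49.1 percentage points lower from compound 2 to compound 3 (beyond the scatter) was large, and a number 20.8 percentage points lower from compound 1 to compound 3 (beyond the scatter) was modest. Compound 4 `Nc1ccccc1NC(=O)c1ccc(CSC(=S)N2CCN(C3CCCCC3)CC2)cc1` differs from compound 3 by cyclohexyl in place of 4-methylphenyl on an amine nitrogen in a ring. Within the data shown here, no measured step exchanges the aromatic ring for a non-aromatic one; the steps of a number 28.3 percentage points higher from compound 1 to compound 2 (beyond the scatter), a number 20.8 percentage points lower from compound 1 to compound 3 (beyond the scatter) and a number 49.1 percentage points lower from compound 2 to compound 3 (beyond the scatter) show only that changes at this ring move this assay in either direction, modestly to largely. Compound 4 is therefore expected to show an uncertain step a number 16 percentage points higher from compound 3 to compound 4 (beyond the scatter), upward because compound 3 stands at 24%. Compound 4 is estimated at 40%, between 12% and 70%.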

Compound 4, a percentage reported as inhibition, at one concentration (the size of the read-out at that concentration, not a potency): 76.1%
Estimate against measurement, compound 4: 36.1 percentage points below; measured number above the stated range.
By their numbers in this assay, from the lowest: compound 3; then compound 1; then compounds 2 and 4 (each within the scatter of the next).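

In this assay, replacing an aromatic ring on this amine nitrogen with a non-aromatic one gave a number 52.1 percentage points higher from compound 3 to compound 4 (beyond the scatter), a number 31.3 percentage points higher from compound 1 to compound 4 (beyond the scatter) and a number 3 percentage points higher from compound 2 to compound 4 (within the scatter). An aromatic ring at this position is thus not required for a high number, and cyclohexyl does not share the low numbers of the 4-methylphenyl and 4-chlorophenyl compounds. No available evidence accounts for this result. As far as these compounds go, whether a smaller ring such as cyclopentyl, an open chain such as butyl, or a hydroxyl group on the cyclohexyl ring would keep the number remains open.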